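The source may hold more compounds than are shown below. What is called first, only, known or untested is meant among the compounds shown, and "the series" means these compounds.

Measured compounds in an ADME assay on HEK293 cells (Homo sapiens) for cytotoxicity, read by MTT assay, with a stated time of 24 h; on this read-out lower numbers stand for stronger inhibition and higher numbers for weaker inhibition:

- compound 1 `O=C1O/C(=C\Cn2cc(Cc3ccccc3)nn2)C(OCc2ccccc2)=C1OCc1ccccc1`: in this assay compound 1 gives 70000 nM
- compound 2 `Cc1ccc(-c2cn(C/C=C3\OC(=O)C(OCc4ccccc4)=C3OCc3ccccc3)nn2)cc1`: for compound 2 this assay reports only a limit, > 100000 nM
- compound 3 `O=C1NC(O)(CCn2cc(Cc3ccccc3)nn2)C(OCc2ccccc2)=C1OCc1ccccc1`: in this assay compound 3 gives 86000 nM

Compound 1 and compound 3 carry different cores; the difference between the two cores is not broken down here. Their numbers in this assay lie within the usual scatter of each other, so no order between compound 1 and compound 3 can be read from them.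

Compound 2 is derived from compound 1 by one change, (4-methylphenyl in place of benzyl on an aromatic carbon). The resulting step is an at least 1.4-fold higher number from compound 1 to compound 2 (0.15 log units; that floor lies within the scatter). Because the value of compound 2 is a limit (the limit of > 100000 nM in this assay, at which 1 of the 3 values shown sits), only a floor for this step is known, and that floor lies within the scatter.

Compound 4 `Cc1ccc(-c2cn(CCC3(O)NC(=O)C(OCc4ccccc4)=C3OCc3ccccc3)nn2)cc1` has not yet been measured. For the measured compounds named here, it is derived from compound 3 by 4-methylphenyl in place of benzyl on an aromatic carbon, the same change at the same place as the one made from compound 1 to compound 2. Resting on the step seen from compound 1 to compound 2, an at least 1.4-fold higher number from compound 1 to compound 2 (0.15 log units; that floor lies within the scatter), the expected step is a 1.5-fold higher number from compound 3 to compound 4 (0.18 log units; within the scatter), that is, a number no lower than that of compound 3 and quite possibly beyond the range of this assay. For compound 4 the estimated value in this assay is 130000 nM, expected between 70000 nM and 250000 nM, with a fair chance that only a limit is reported.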

Compound 4, half-maximal inhibitory concentration: 45000 nM
Estimate against measurement, compound 4: 2.9-fold (0.46 log units) above; measured number outside the range, below it.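

In this assay, 4-methylphenyl in place of benzyl gives a 1.9-fold lower number from compound 3 to compound 4 (0.28 log units; within the scatter), and the step seen on the core of compound 1 does not carry over to the core of compound 3: the same change on two cores in this assay, an at least 1.4-fold higher number (0.15 log units; that floor lies within the scatter) from compound 1 to compound 2 and a 1.9-fold lower number (0.28 log units; within the scatter) from compound 3 to compound 4, at least 2.7-fold (0.43 log units) apart, beyond the scatter of two such steps

This shows that, for these two pairs, the step on one core is a poor guide to the step on the other, yet each step taken alone stays within the scatter, so neither shows that the change itself moves the number on its core. The comparison rests on a single pair per core, and compound 2 gives a limit rather than a number, so the step on the core of compound 1 is known only as a floor: the limit of > 100000 nM in this assay, at which 1 of the 4 values shown sits.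

The two cores differ in more than one feature, and the compounds shown do not tell which part of the core goes with the gap between the steps. Going by these compounds, it also remains open whether the two cores would part in the same way with other groups at this place, such as an amine or a carboxylic acid in place of 4-methylphenyl.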